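A few compounds are considered here, and "the series" means these few. Any claim that something is new, unique, unknown or untested is made for them only; others in the source may bear on it.

Measured in a physicochemical assay for lipophilicity, read by HPLC, in phosphate buffer, measured as octanol-water partition, at pH 7.4, tested at 100 uM; on this read-out lower numbers stand for lower lipophilicity and higher numbers for higher lipophilicity:
- compound 1 `COCCOc1cc(C)c(-c2cccc(CNc3ccc(OCC(=O)O)c(F)c3)c2)c(C)c1` gives 2.47
- compound 2 `O=C(O)COc1ccc(NCc2ccc(Cl)c(-c3ccccc3)c2)cc1F` gives 2.74
- compound 3 `Cc1ccccc1-c1cccc(CNc2ccc(OCC(=O)O)c(F)c2)c1` gives 2.41

On these numbers, compound 3 stands within the scatter of compound 1, while compound 2 lies higher than compound 3, beyond the scatter. Compound 4 `Cc1cc(O)ccc1-c1cccc(CNc2ccc(OCC(=O)O)c(F)c2)c1` differs from compound 3 in one place: hydroxy in place of hydrogen on an aromatic carbon with hydroxy in place of hydrogen on an aromatic carbon, so 2-methylphenyl becomes 4-hydroxy-2-methylphenyl. For the measured compounds named here, no measured pair here shows this change, so the expectation rests on the structural change alone. A downward move in this assay is expected, and the expected size is a number 0.46 log units lower from compound 3 to compound 4 (beyond the scatter) which would lie beyond the scatter. The estimated value for compound 4 is 1.95 with an expected range from 1.55 to 2.35 on this scale.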

Compound 4, distribution coefficient: 1.85
For compound 4 the middle estimate is 0.10 log units above the measured one; measured number inside the range.
By their numbers in this assay, from the lowest: compound 4; then compounds 3, 1 and 2 (each within the scatter of the next, the first and the last beyond it).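

In this assay, hydroxy in place of hydrogen gives the first step in the set that can be read at a single place, a number 0.56 log units lower from compound 3 to compound 4 (beyond the scatter), so this aromatic carbon, para to a large group and meta to a methyl group, is shown to matter for this read-out. A single added heavy atom is enough to produce this step. Nothing available bears on why the number moves. Going by these compounds, whether a methoxy group or an amine at this carbon would give a step of similar size remains open, as does the effect of hydroxy elsewhere on this ring.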